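The source may hold more compounds than are shown below. What is called first, only, known or untested is meant among the compounds shown, and "the series" means these compounds.

Measured compounds:
- compound 1, `COc1ccc2nc(C(=O)Nc3ccc(-c4ccccc4)cc3)c(C)c(O)c2c1`, 14.2%
- compound 2, `Cc1c(C(=O)Nc2ccc(-c3ccccc3)cc2)nc2ccccc2c1O`, 14.3%
- compound 3, `COc1ccc2nc(C(=O)Nc3ccc(-c4ccccc4)cc3)c(C)c(C(=O)O)c2c1`, 11.3%

In a functional assay on Hep 3B2 cells (Homo sapiens) for antiproliferative activity, read by MTT assay, with a stated time of 24 h, tested at 1.23 ug/mL (on this read-out higher numbers stand for a stronger effect at the one concentration tested and lower numbers for a weaker effect), compound 3 gives a number that differs from those of compound 1 and compound 2 by less than the scatter, so the three cannot be told apart on this read-out.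

Compound 4 is `Cc1c(C(=O)Nc2ccc(-c3ccccc3)cc2)nc2ccccc2c1C(=O)O`; it has not been measured. Its change from compound 3 is hydrogen in place of methoxy on an aromatic carbon. The same change has been made once before in this series: a number 0.1 percentage points higher from compound 1 to compound 2 (within the scatter), a step that left the read-out unchanged. Among the measured compounds shown here, the step of a number 2.9 percentage points lower from compound 1 to compound 3 (within the scatter) is the one that produced compound 3 itself and also stayed within the scatter. Nothing measured here points to any effect of the present change, and none beyond the scatter is expected.

Compound 4 is therefore estimated at 11.5%, within 3% to 20%, which means an expected step of a number 0.2 percentage points higher from compound 3 to compound 4 (within the scatter).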

Compound 4, a percentage reported as inhibition, at one concentration (the size of the read-out at that concentration, not a potency): 1.25%
For compound 4 the middle estimate is 10.3 percentage points above the measured one, and the stated range ends above it.
By their numbers in this assay, from the lowest: compound 4; then compounds 3, 1 and 2 (each within the scatter of the next).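

In this assay, among the compounds shown here, hydrogen in place of methoxy and carboxy in place of hydroxy, both within the scatter on the earlier compounds, now each give a step beyond it: a number 10.1 percentage points lower from compound 3 to compound 4 (beyond the scatter), and a number 13.1 percentage points lower from compound 2 to compound 4 (beyond the scatter). This hints that the two changes act together on the shared core, but for hydrogen in place of methoxy the hint stays unproven, as the steps on the two cores cannot be separated: the same change on two cores in this assay, a number 0.1 percentage points higher (within the scatter) from compound 1 to compound 2 and a number 10.1 percentage points lower (beyond the scatter) from compound 3 to compound 4, 10.2 percentage points apart, within the scatter of two such steps The same caution holds for carboxy in place of hydroxy: the same change on two cores in this assay, a number 2.9 percentage points lower (within the scatter) from compound 1 to compound 3 and a number 13.1 percentage points lower (beyond the scatter) from compound 2 to compound 4, 10.2 percentage points apart, within the scatter of two such steps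

Going by these compounds, whether an ethoxy group or an amine on the same aromatic carbon would keep the number of compound 3 or give a step like that to compound 4 remains open. Also open, on these data alone, is whether these steps would hold at other concentrations, as a single concentration gives no potency.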